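Amide aryl swap on a shared chromone core

The compounds below may be only part of what the source reports. "The series", "measured", "known", "first", "only" and "open" are said of these compounds alone.

compound 1 `COc1cc2oc(-c3cccc(NC(=O)c4ccc(F)cc4)c3)cc(=O)c2c(OC)c1OC` — "active" (no number reported)
compound 2 `COc1cc2oc(-c3cccc(NC(=O)c4ccc(Cl)cc4)c3)cc(=O)c2c(OC)c1OC` — 51.1%

In a functional assay on UO-31 cells (Homo sapiens) for inhibition, read by sulforhodamine B assay, tested at 10 uM (on this read-out lower numbers stand for less inhibition and higher numbers for more inhibition at the one concentration tested (going by the name of the read-out)), compound 2 gives 51.1%. Among the measured compounds shown here, compound 1 is recorded in this assay only as "active" (no number reported), without a number, so compound 2 holds the single number of the series and no order between the two compounds can be drawn.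

Compound 3 `COc1cc2oc(-c3cccc(NC(=O)c4ccccc4Br)c3)cc(=O)c2c(OC)c1OC` has not been measured. Its difference from compound 2 is counted below.

2-bromophenyl in place of 4-chlorophenyl on a carbonyl carbon

For the measured compounds named here, no step between measured compounds is known, so there is no measured guide to how much such a change moves the read-out in this assay. The expectation is a step within the scatter, if anything a slight fall, and the estimate means a number 7.1 percentage points lower from compound 2 to compound 3 (within the scatter). Compound 3 is expected to give 44% in this assay, with a range from 22% to 66%.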

Compound 3, a percentage reported as inhibition, at one concentration (the size of the read-out at that concentration, not a potency): "active" (no number reported)
No number was reported for compound 3; there is nothing to compare the estimate with.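

In this assay, among the compounds shown here, compound 3 is recorded as "active" (no number reported) without a number, so no step from compound 2 can be read. No evidence bears on this result. Still open, from the compounds shown here alone, is how compound 1 and compound 3 stand numerically against compound 2, and how far 2-bromophenyl in place of 4-chlorophenyl moves the read-out.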